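A few compounds are considered here, and "the series" means these few. Any claim that something is new, unique, unknown or untested is made for them only; others in the source may bear on it.

Compound 1 `CC(C)COC(=O)N1CCC(Oc2ncnc3c2CCN3c2ccc(S(C)(=O)=O)cc2F)CC1` and compound 2 `CC(C)SC(=O)N1CCC(Oc2ncnc3c2CCN3c2ccc(S(C)(=O)=O)cc2F)CC1` share one core and differ only in the group on the carbonyl carbon. Among the compounds with values here, in a functional assay on CHO-K1 cells with Glucose-dependent insulinotropic receptor (Homo sapiens) as the target, read by a luciferase reporter, with a stated time of 5 h (a higher number here means a larger maximal response, a lower number a smaller maximal response), compound 1 gives 94% and compound 2 gives 138%; the step of a number 44 percentage points higher from compound 1 to compound 2 (beyond the scatter) is the only change measured so far. Compound 2 thus stands highest of the two numbers, with compound 1 as its nearest neighbour. Compound 3 `CC(C)S(=O)(=O)N1CCC(Oc2ncnc3c2CCN3c2ccc(S(C)(=O)=O)cc2F)CC1` is not yet measured; it differs from compound 2 by isopropylsulfonyl in place of (isopropylsulfanyl)carbonyl on an amine nitrogen in a ring. Within the data shown here, the single measured step sits at the same place but keeps the carbonyl, whereas here the carbonyl itself goes, so no measured step covers a sulfonyl at this position. The expectation rests loosely on compound 2 and is estimated to give back part of its gain, an expected step of a number 28 percentage points lower from compound 2 to compound 3 (beyond the scatter). For compound 3 the estimated value in this assay is 110%, with a range from 70% to 150%.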

Compound 3, largest response reached (reported as percent of maximum), in percent of the reference or control that the assay uses: 62%
Beside the measured number, compound 3's estimate is 48 percentage points above it; measured number outside the range, below it.
By their numbers in this assay, from the lowest: compound 3; then compound 1; then compound 2.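

In this assay the change to isopropylsulfonyl on the amine nitrogen in a ring gives a number 76 percentage points lower from compound 2 to compound 3 (beyond the scatter) and also a number 32 percentage points lower from compound 1 to compound 3 (beyond the scatter) so the sulfonyl compound sits lowest of the three, under both carbonyl compounds. The earlier pair showed only that the maximal response moves with the group on the carbonyl carbon; the new steps show that removing the carbonyl in favour of a sulfonyl lowers it, even though the heavy-atom count stays the same from compound 2 to compound 3. No measurement at hand accounts for this drop.

From the compounds shown here alone, whether the loss follows from the sulfonyl itself or from the absence of the carbonyl remains open. A urea or a simple amide on the same nitrogen, and sulfonyl groups carrying a longer chain or a phenyl ring, would help separate these two readings.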